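This account rests on a few compounds, and the source may have more. Where it says the series, first, only, none or still open, it means among the compounds named here.

Among the compounds with values here, in an assay on HeLa cells for inhibition of Indoleamine 2,3-dioxygenase 1 (Homo sapiens), with a stated time of 48 h (on this read-out lower numbers stand for stronger inhibition and higher numbers for weaker inhibition), compound 2 `COCCNc1nonc1/C(=N/O)Nc1ccc(F)c(Br)c1` gives 100 nM, the lowest of the two numbers so far. Within the data shown here, its only neighbour, compound 1 `O/N=C(\Nc1ccc(F)c(Br)c1)c1nonc1NCc1ccccc1`, gives 280 nM, and the step of a 2.8-fold lower number from compound 1 to compound 2 (0.45 log units; beyond the scatter) is a modest one. Compound 3 `CC(=O)NCCNc1nonc1/C(=N/O)Nc1ccc(F)c(Br)c1` differs from compound 2 by acetamido in place of methoxy on a saturated chain carbon, two bonds along the chain from a nitrogen on an aromatic ring. No measured step swaps these two groups, and the one step shown replaces a different group on the same chain, so no clear direction follows from it. Compound 3 is therefore expected to differ little, the expected step being a 1.3-fold higher number from compound 2 to compound 3 (0.11 log units; within the scatter). The estimate for compound 3 is 130 nM, with a range from 50 nM to 350 nM.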

Compound 3, half-maximal inhibitory concentration: 17 nM
Beside the measured number, compound 3's estimate is 7.6-fold (0.88 log units) above it; the whole stated range lies above it.
By their numbers in this assay, from the lowest: compound 3; then compound 2; then compound 1.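

In this assay the far end of the chain on the ring nitrogen still has room to matter: acetamido in place of methoxy brings a 5.9-fold lower number from compound 2 to compound 3 (0.77 log units; beyond the scatter) and so changes the result even when no ring is involved. Acetamidomethyl in place of phenyl brings a 16-fold lower number from compound 1 to compound 3 (1.22 log units; beyond the scatter) and is a large step. Nothing available here explains this gain. From the compounds shown here alone, it remains open whether the amide hydrogen or the carbonyl of the acetamido group matters more. Going by these compounds, it also remains open how an amine, a carboxylic acid or a longer chain would compare at this position.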